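A few compounds are considered here, and "the series" means these few. Any claim that something is new, unique, unknown or untested is made for them only; others in the source may bear on it.

Measured compounds:
compound 1 `CCN(CC)C(=S)N/N=C1\C(=O)Nc2ccccc21`: > 25000 nM
compound 2 `Cc1ccccc1NC(=S)N/N=C1\C(=O)Nc2ccccc21`: > 25000 nM

In an ADME assay on RD cells (Homo sapiens) for cytotoxicity (a higher number here means that more compound is tolerated, a lower number that less compound is tolerated), compound 1 gives > 25000 nM, which is a limit of the assay rather than a number. Compound 2 gives > 25000 nM in this assay, likewise a limit. Both measured values sit at the limit of > 25000 nM in this assay, at which 2 of the 2 values shown sit. Compound 3 `CCCNC(=S)N/N=C1\C(=O)Nc2ccccc21` differs from compound 2 by propyl in place of 2-methylphenyl on an amide-type nitrogen. For the measured compounds named here, no step between measured compounds is available to compare with. The step expected in this assay is a step that the limit leaves unreadable from compound 2 to compound 3, that is, none beyond the scatter. This expectation rests on compound 2 sitting at the limit of > 25000 nM in this assay, at which 2 of the 2 values shown sit. Compound 3 is therefore expected to give about 30000 nM, within a range from 10000 nM to 100000 nM.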

Compound 3, half-maximal cytotoxic concentration: > 25000 nM
Compound 3: a limit, no number (the forecaster's own chance of this, stated with the estimate: 80%); the middle value lies beyond the limit too.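

Compound 3 gives > 25000 nM in this assay, again a limit and not a number, so its steps from compound 1 and compound 2 cannot be read. How much of each of these three compounds the cells tolerate stays open: the limit of > 25000 nM in this assay, at which 3 of the 3 values shown sit.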